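A few compounds are considered here, and "the series" means these few. Any claim that something is new, unique, unknown or untested is made for them only; others in the source may bear on it.

Working notes on the series. Three analogues of the shared core differ only in the group carried on a double-bonded chain carbon bound to a double-bonded chain carbon. In a functional assay on HeLa cells (Homo sapiens) for cytotoxicity, read by WST assay, with a stated time of 48 h (on this read-out lower numbers stand for stronger inhibition and higher numbers for weaker inhibition), compound 1 `COc1ccc(/C=C/C[C@H]2C[C@@H]([C@@H](O)c3ccccc3)CO[C@@H]2c2ccccc2)cc1` gives 8300 nM. Compound 2 `COc1ccccc1/C=C/C[C@H]1C[C@@H]([C@@H](O)c2ccccc2)CO[C@@H]1c1ccccc1` gives 14700 nM, and compound 3 `O[C@@H](c1ccccc1)[C@H]1CO[C@H](c2ccccc2)[C@@H](C/C=C/C2CCCCC2)C1` gives 6440 nM in this assay. Going by the values given here, compound 3 holds the lowest of the three numbers, but the step of a 1.3-fold lower number from compound 1 to compound 3 (0.11 log units; within the scatter) does not separate it from compound 1; only the step of a 2.3-fold lower number from compound 2 to compound 3 (0.36 log units; beyond the scatter) is beyond the scatter. The step of a 1.8-fold higher number from compound 1 to compound 2 (0.25 log units; within the scatter) is likewise within the scatter.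

Compound 4 `CCCCCC/C=C/C[C@H]1C[C@@H]([C@@H](O)c2ccccc2)CO[C@@H]1c1ccccc1` is the next member. Relative to compound 3 the change is hexyl in place of cyclohexyl on a double-bonded chain carbon bound to a double-bonded chain carbon. Among the compounds with values here, no measured step bears directly on it: each of the three steps exchanges one ring for another at the same place, and the one step that moves beyond the scatter, the step from compound 2 to compound 3, is modest. On that basis no step beyond the scatter is expected in this assay for the exchange of a ring for a chain, with a slight lean toward a higher number.

Compound 4 is therefore estimated at 8000 nM in this assay, with a range of 3500 nM to 18000 nM. The expected step is a 1.2-fold higher number from compound 3 to compound 4 (0.09 log units; within the scatter).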

Compound 4, half-maximal inhibitory concentration: 7400 nM
The estimate for compound 4 lay 1.1-fold (0.03 log units) above the measured number; the range from low to high includes it.
By their numbers in this assay, from the lowest: compounds 3, 4, 1 and 2 (each within the scatter of the next, the first and the last beyond it).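

In this assay, the open hexyl chain takes the place of the cyclohexyl ring with no step beyond the scatter (a 1.1-fold higher number from compound 3 to compound 4 (0.06 log units; within the scatter)), so among the compounds shown, a ring on a double-bonded chain carbon bound to a double-bonded chain carbon is not needed to keep the number in this range. Going by these compounds alone, the earlier exchanges were all ring for ring, and this is the first that removes the ring while the heavy-atom count stays the same. Hexyl is also not separated from either aryl group, neither from 4-methoxyphenyl (a 1.1-fold lower number from compound 1 to compound 4 (0.05 log units; within the scatter)) nor from 2-methoxyphenyl (a 2.0-fold lower number from compound 2 to compound 4 (0.30 log units; within the scatter)), whereas cyclohexyl is separated from 2-methoxyphenyl, and no evidence at hand accounts for any of these numbers.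

On these data alone, the four compounds carry only hydrocarbon or methoxy-bearing aryl groups at this place, so it stays open whether a chain ending in an amine or a carboxylic acid would move the number beyond the scatter. As far as these compounds go, it also stays open whether a longer chain such as decyl, or a shorter one such as ethyl, would do so, and whether the number depends on this group at all.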